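Shortening the amine chain from compound 2 to compound 4

This account rests on a few compounds, and the source may have more. Where it says the series, first, only, none or still open, it means among the compounds named here.

Three compounds sharing one core have been examined in an ADME assay on Huh-7 cells (Homo sapiens) for cytotoxicity; on this read-out higher numbers stand for lower toxicity in this test and lower numbers for higher toxicity in this test. Compound 2 `CN1CCN(CCCNCc2cn(-c3ccc(C(F)(F)F)cc3)nc2-c2ccc(C(F)(F)F)cc2)CC1` gives 2000 nM, compound 1 `CN1CCN(CCCNCc2cn(-c3ccc(C(F)(F)F)cc3)nc2-c2ccc(OC(F)(F)F)cc2)CC1` gives 2300 nM, and compound 3 `CN1CCN(CCCNCc2cn(-c3ccc([N+](=O)[O-])cc3)nc2-c2ccc(C(F)(F)F)cc2)CC1` gives 4900 nM. Compound 2 thus holds the lowest of the three numbers, though its nearest neighbour sits within the scatter: the step of a 1.2-fold lower number from compound 1 to compound 2 (0.06 log units; within the scatter) is small, whereas the step of a 2.5-fold higher number from compound 2 to compound 3 (0.39 log units; beyond the scatter) goes beyond the scatter.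

Compound 4 `CN1CCN(CCNCc2cn(-c3ccc(C(F)(F)F)cc3)nc2-c2ccc(C(F)(F)F)cc2)CC1` differs from compound 2 only in the chain: 4-methylpiperazin-1-yl in place of (4-methylpiperazin-1-yl)methyl on a saturated chain carbon, two bonds along the chain from an amine nitrogen. Both measured steps concern a group on an aromatic carbon, and none touches the chain, so neither bears directly on this change. With no shown step to draw on, a change beyond the scatter in this assay is not expected in either direction. The estimate for compound 4 is therefore 2000 nM, with a range of 1000 nM to 4000 nM, which means an expected step of no change at the digits printed from compound 2 to compound 4 (within the scatter).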

Compound 4, half-maximal cytotoxic concentration: 1500 nM
For compound 4 the middle estimate is 1.3-fold (0.12 log units) above the measured one; measured number inside the range.
By their numbers in this assay, from the lowest: compounds 4, 2 and 1 (each within the scatter of the next); then compound 3.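

In this assay, going from the 3-(4-methylpiperazin-1-yl)propyl chain to the 2-(4-methylpiperazin-1-yl)ethyl chain gives a 1.3-fold lower number from compound 2 to compound 4 (0.12 log units; within the scatter), so this read-out does not separate the two chains in this pair. For the compounds shown here, this is the first look at the chain rather than at a group on an aromatic carbon, and the change stays within the scatter, unlike the step from trifluoromethyl to nitro, a 2.5-fold higher number from compound 2 to compound 3 (0.39 log units; beyond the scatter). Nothing measured here offers an explanation for this result.

As far as these compounds go, whether a longer chain such as 4-(4-methylpiperazin-1-yl)butyl, or a morpholine in place of the 4-methylpiperazin-1-yl group, would move the number beyond the scatter remains open. From the compounds shown here alone, it is also open whether the same chain change would hold with nitro on the aromatic ring, as in compound 3.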